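The source may report more compounds than this note shows. Statements on the series, on what has been measured and on what is new or still open speak of the compounds shown alone.

Working notes on the series. Compound 1 `O=C(O)CCCCCCCCCCCOc1ccc2c(=O)c(-c3ccc(O)cc3)coc2c1` stands lowest of the two numbers in hand in an assay (Cricetulus griseus) for inhibition of aldehyde dehydrogenase, mitochondrial (Homo sapiens) (on this read-out lower numbers stand for stronger inhibition and higher numbers for weaker inhibition), where compound 1 gives 130 nM. Among the compounds with values here, the only other measured member, compound 2 `O=C(O)CCCCCOc1ccc2c(=O)cc(-c3ccc(O)cc3)oc2c1`, gives 3500 nM in this assay, a gap beyond the scatter; compound 2 differs from compound 1 both in the core and in the chain, so the two values show only that compound 1 sits well below compound 2 and assign nothing to either change on its own. Compound 3 `O=C(O)CCCCCCCCCOc1ccc2c(=O)c(-c3ccc(O)cc3)coc2c1` keeps the core of compound 1 and alters only the chain: carboxy in place of 2-carboxyethyl on a saturated chain carbon, nine bonds along the chain from an oxygen on an aromatic ring. Within the data shown here, no measured pair differs at this spot alone, so the step has to be judged from the direction the two numbers point: compound 1, with the longer chain, gives 130 nM, the lower of the two. Shortening the chain is therefore expected to move the number up somewhat, a step of a 1.9-fold higher number from compound 1 to compound 3 (0.28 log units; within the scatter) that may still fall within the scatter. Compound 3 is expected to give 250 nM in this assay, with a range from 100 nM to 700 nM.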

Compound 3, half-maximal inhibitory concentration: 50 nM
Compound 3: middle estimate off by 5.0-fold (0.70 log units), on the high side; measured number outside the range, below it.
By their numbers in this assay, from the lowest: compound 3; then compound 1; then compound 2.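

In this assay, within the data shown here, the first comparison at this spot alone gives a 2.6-fold lower number from compound 1 to compound 3 (0.41 log units; beyond the scatter), a modest step beyond the scatter, for carboxy in place of 2-carboxyethyl on a saturated chain carbon, nine bonds along the chain from an oxygen on an aromatic ring. The earlier pair changed core and chain together, whereas this step shows that the chain alone moves the number on the shared core, and that over this one step the longer chain does not give the lower number. Nothing in hand explains the direction of this step.

From the compounds shown here alone, two chain lengths on one core set no trend, so it remains open whether a chain shorter than that of compound 3 would lower the number further or raise it again, and whether an amide or a tetrazole in place of the terminal carboxylic acid would keep the number of compound 3. Going by these compounds, how much of the gap to compound 2 belongs to the core also stays open, since that would need the core of compound 2 carrying the chain of compound 1 or compound 3.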